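Moving the hydroxy group on the benzyl ring of compound 3

The source may hold more compounds than are shown below. What is called first, only, known or untested is meant among the compounds shown, and "the series" means these compounds.

Compound 1 `N#Cc1ccc(Cn2cncc2-c2cc3cc(Br)ccc3[nH]2)cc1`: 6920 nM
Compound 2 `Nc1ccccc1Cn1cncc1-c1cc2cc(Br)ccc2[nH]1`: 12000 nM
Compound 3 `Oc1ccccc1Cn1cncc1-c1cc2cc(Br)ccc2[nH]1`: 5010 nM

Of the compounds shown here, three sharing one core have been measured in an assay on HEK293 cells for inhibition of Indoleamine 2,3-dioxygenase 1 (Homo sapiens), with a stated time of 30 min; on this read-out higher numbers stand for an effect only at larger amounts of compound and lower numbers for an effect already at smaller amounts. Compound 3 gives the lowest of the three numbers; its nearest neighbour is compound 1, with a 1.4-fold lower number from compound 1 to compound 3 (0.14 log units; within the scatter), while the gap to compound 2 is larger, with a 2.4-fold lower number from compound 2 to compound 3 (0.38 log units; beyond the scatter). The remaining measured step, a 1.7-fold higher number from compound 1 to compound 2 (0.24 log units; within the scatter), shows that exchanging the 4-cyanophenyl for a 2-aminophenyl also stays within the scatter.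

Compound 4 `Oc1cccc(Cn2cncc2-c2cc3cc(Br)ccc3[nH]2)c1` is to be measured in this assay. It differs from compound 3 as follows: 3-hydroxyphenyl in place of 2-hydroxyphenyl on a saturated chain carbon bound to an aromatic nitrogen. For the measured compounds named here, no measured step moves a group around the phenyl ring; the steps seen so far either swap the group on that ring or exchange the whole phenyl, and all of them are small, two within the scatter and one modest. On that basis compound 4 is expected to sit close to compound 3, with an estimated step of a 1.1-fold higher number from compound 3 to compound 4 (0.04 log units; within the scatter), most likely within the scatter. The estimate for compound 4 is therefore 5500 nM, with a range from 2000 nM to 15000 nM.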

Compound 4, half-maximal effective concentration: 9970 nM
Compound 4: middle estimate off by 1.8-fold (0.26 log units), on the low side; measured number inside the range.
By their numbers in this assay, from the lowest: compounds 3, 1, 4 and 2 (each within the scatter of the next, the first and the last beyond it).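

In this assay, for the compounds shown here, 3-hydroxyphenyl in place of 2-hydroxyphenyl is the first measured move of a group around the phenyl ring, with the atoms and the donor and acceptor counts unchanged, and it gives a 2.0-fold higher number from compound 3 to compound 4 (0.30 log units; within the scatter) as its step, so at this position the move from 2-hydroxyphenyl to 3-hydroxyphenyl does not separate the two compounds beyond the scatter. Compound 4 also stays within the scatter of the compounds carrying the other rings, with a 1.2-fold lower number from compound 2 to compound 4 (0.08 log units; within the scatter) as one step and a 1.4-fold higher number from compound 1 to compound 4 (0.16 log units; within the scatter) as the other, which leaves the gap between compound 2 and compound 3 as the only one of the listed steps beyond the scatter, and compound 4 does not widen that spread. Nothing available accounts for the size of the step between compound 3 and compound 4.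

The compounds shown leave open whether a 4-hydroxyphenyl would stay within the scatter of these two, and whether a methoxy group in place of the hydroxy would do the same. They also leave open whether a carboxylic acid on the ring, or a longer chain to the aromatic nitrogen, would give a step beyond the scatter.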